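Aryl ether change on the shared core, permeability expectation

The source may report more compounds than this note shows. Statements on the series, on what has been measured and on what is new or still open speak of the compounds shown alone.

Compound 1 `COc1cccc(Oc2ccc3c(NCCCNCc4cc(F)ccc4OC)ccnc3c2)c1` gives 317 10^-6 cm/s in an ADME assay for permeability, using PAMPA, with a stated time of 30 min, at pH 7.4; a lower number here means that the compound crosses the layer more slowly, a higher number that the compound crosses the layer faster. Compound 2 `COc1cccc(Oc2ccc3c(NCCCNCc4ccco4)ccnc3c2)c1` gives 317 10^-6 cm/s in this assay, and compound 3 `COc1cccc(Oc2ccc3c(NCCCNCc4cccc(OC)c4O)ccnc3c2)c1` gives 317 10^-6 cm/s. Compound 1 therefore stands level with both: the step of no change at the digits printed from compound 1 to compound 2 (within the scatter) and the step of no change at the digits printed from compound 1 to compound 3 (within the scatter) are both flat, as is no change at the digits printed from compound 2 to compound 3 (within the scatter).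

Compound 4 `COc1ccc(F)cc1CNCCCNc1ccnc2cc(Oc3cccc(N(C)C)c3)ccc12` differs from compound 1 by dimethylamino in place of methoxy on an aromatic carbon. Among the measured compounds shown here, none of the measured steps touches this position; all three exchange the group on the saturated chain carbon bound to the amine nitrogen, and each of them left the read-out in this assay unchanged within the scatter. They bear on compound 4 only in showing that three quite different groups elsewhere on the same core gave the same value, so no basis exists for expecting the present exchange to move the number. The expected step of no change at the digits printed from compound 1 to compound 4 (within the scatter) is therefore none beyond the scatter. Compound 4 is estimated at 317 10^-6 cm/s in this assay, with a range from 160 10^-6 cm/s to 450 10^-6 cm/s.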

Compound 4, apparent permeability: 317 10^-6 cm/s
Estimate against measurement, compound 4: no gap at the digits printed; low and high end bracket the measured number.
By their numbers in this assay, from the lowest: compounds 1, 2, 3 and 4 (each within the scatter of the next).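

Among the compounds shown here, the first reading on the aryl ether side of the shared core gives no change at the digits printed from compound 1 to compound 4 (within the scatter) in this assay, with 3-(dimethylamino)phenoxy in place of 3-methoxyphenoxy. The earlier steps shown here all lay on the saturated chain carbon bound to the amine nitrogen, so the level read-out now reaches a second place on the molecule, though at this place it rests on this single exchange. No measurement in hand offers an explanation for this level result.

As far as these compounds go, whether a carboxylic acid on this aromatic carbon would also leave the read-out level stays open. Also open, from the compounds shown here alone, is whether a longer chain linking the two amine nitrogens would do the same, since all four compounds share one chain and one printed value.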